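Compound 2 to compound 3: a new group on nitrogen

This account rests on a few compounds, and the source may have more. Where it says the series, first, only, none or still open, it means among the compounds named here.

In a functional assay on GOTO cells (Homo sapiens) for cytotoxicity, read by MTT assay, with a stated time of 3 days (a higher number here means a weaker inhibitor, a lower number a stronger inhibitor), compound 1 (`CNc1nc(SCc2nc3ccccc3[nH]2)nc(-c2ccccc2)c1C#N`) gives 3.28 nM and compound 2 (`N#Cc1c(Nc2ccccn2)nc(SCc2nc3ccccc3[nH]2)nc1-c1ccccc1`) gives 2.5 nM, so compound 2 stands level with compound 1, within the scatter. Compound 3 (`N#Cc1c(NNC(N)=S)nc(SCc2nc3ccccc3[nH]2)nc1-c1ccccc1`) is the next structure to be read, and its change from compound 2 sits on a nitrogen on an aromatic ring: a group of 4 heavy atoms (1 carbon, 2 nitrogen, 1 sulfur; no ring) in place of a group of 6 heavy atoms (5 carbon, 1 nitrogen; one six-membered aromatic ring with 1 hetero atom), on a nitrogen on an aromatic ring. Going by the values given here, one measured step bears on this place, a 1.3-fold lower number from compound 1 to compound 2 (0.12 log units; within the scatter), where pyridin-2-yl took the place of methyl. Among the compounds with values here, that is thin evidence, since it is a single step, and no measured compound carries a group like the one entering here. With that step inside the scatter, no shift beyond the scatter is expected in this assay, and no direction is favoured. The expected step is a 1.4-fold higher number from compound 2 to compound 3 (0.15 log units; within the scatter). For compound 3 the estimate is 3.5 nM, with an expected range of 1 nM to 12 nM.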

Compound 3, half-maximal inhibitory concentration: 2.55 nM
Estimate against measurement, compound 3: 1.4-fold (0.14 log units) above, within the range that was stated.
By their numbers in this assay, from the lowest: compounds 2, 3 and 1 (each within the scatter of the next).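

Working notes on the nitrogen on an aromatic ring: in this assay, the open-chain group bearing a double bond outside aromatic rings reads level with pyridin-2-yl (a 1.0-fold higher number from compound 2 to compound 3 (0.01 log units; within the scatter)), so a group with no ring matches the aromatic one here. It also reads level with methyl (a 1.3-fold lower number from compound 1 to compound 3 (0.11 log units; within the scatter)), which leaves the methyl, pyridin-2-yl and open-chain groups of compounds 1, 2 and 3 indistinguishable at this place, despite their different sizes and donor counts. No measurement shown accounts for this flat reading.

On these data alone, whether the numbers stay level with a carboxylic acid, a simple unsubstituted amine or a longer alkyl chain on this nitrogen remains open. So does whether a phenyl ring, with no hetero atom, reads like pyridin-2-yl.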